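The compounds below may be only part of what the source reports. "The series", "measured", "known", "first", "only" and "open" are said of these compounds alone.

In a functional assay on MKN-74 cells (Homo sapiens) for antiproliferative activity, with a stated time of 24 h (on this read-out higher numbers stand for weaker inhibition and lower numbers for stronger inhibition), the three measured compounds read as follows.

Compound 1 `NC(=O)c1c(NC(=O)c2ccccc2Cl)sc2c1CCN(Cc1ccc([N+](=O)[O-])cc1)C2`: 31500 nM
Compound 2 `NC(=O)c1c(NC(=O)c2ccc(C(F)(F)F)cc2)sc2c1CCN(Cc1c(Cl)cccc1Cl)C2`: 8530 nM
Compound 3 `NC(=O)c1c(NC(=O)c2ccccc2F)sc2c1CCN(Cc1cccc(Cl)c1)C2`: 23300 nM

Compound 1 stands highest of the three numbers. Its nearest neighbour is compound 3, whose value lies within the scatter, so no order can be drawn between those two; compound 2 sits furthest from it, beyond the scatter. Compound 4 `NC(=O)c1c(NC(=O)c2ccccc2Cl)sc2c1CCN(C(=S)Nc1ccccc1I)C2` has not yet been tested in this assay. It differs from compound 1 in one place: a group of 10 heavy atoms (7 carbon, 1 nitrogen, 1 sulfur, 1 iodine; one six-membered aromatic ring of carbon only) in place of a group of 10 heavy atoms (7 carbon, 1 nitrogen, 2 oxygen; one six-membered aromatic ring of carbon only), on an amine nitrogen in a ring. For the measured compounds named here, no measured pair shows this change, so the data give no guide to it, and the step is expected to be a 1.4-fold lower number from compound 1 to compound 4 (0.16 log units; within the scatter), not beyond the scatter. Compound 4 is therefore expected to give about 22000 nM in this assay, within a range from 6000 nM to 80000 nM.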

Compound 4, half-maximal inhibitory concentration: 2630 nM
Compound 4: the middle estimate sits 8.4-fold (0.92 log units) above what was measured, outside the stated range (below it).
By their numbers in this assay, from the lowest: compound 4; then compound 2; then compounds 3 and 1 (each within the scatter of the next).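

At the amine nitrogen in the ring, putting the sulfur- and iodine-bearing group in place of 4-nitrobenzyl gives, in this assay, a 12-fold lower number from compound 1 to compound 4 (1.08 log units; beyond the scatter). For the compounds shown here, the earlier compounds offered no single-place step, so this is the first sign that this position alone can move the read-out beyond the scatter. Nothing available accounts for the size of this step.

The sulfur and the iodine enter together, so their separate shares cannot be told apart. Going by these compounds, how a urea with oxygen in place of that sulfur, or a bromine in place of the iodine, would read remains open.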